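Phenyl for 2-methoxybenzyl: a step from compound 2

This account rests on a few compounds, and the source may have more. Where it says the series, first, only, none or still open, it means among the compounds named here.

compound 1, `CCOC(=O)c1cccc(-c2n[nH]c3ccccc23)c1`: > 10000 nM
compound 2, `CCOC(=O)c1ccc(-c2nn(Cc3ccccc3OC)c3ccccc23)cc1`: > 10000 nM
compound 3, `CCCNC(=O)c1ccc(-c2nn(Cc3ccccc3)c3ccccc23)cc1`: > 10000 nM

In a functional assay on cells (Platelet, Homo sapiens) for inhibition (a lower number here means a stronger inhibitor, a higher number a weaker inhibitor), compound 1 gives > 10000 nM, which is a limit of the assay rather than a number. Compound 2 gives > 10000 nM, likewise a limit. Compound 3 gives > 10000 nM, also a limit. Compound 2 therefore stands with both others at the limit of > 10000 nM in this assay, at which 3 of the 3 values shown sit; no measured value here is a real number.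

Compound 4, `CCOC(=O)c1ccc(-c2nn(-c3ccccc3)c3ccccc23)cc1`, differs from compound 2 in one place: phenyl in place of 2-methoxybenzyl on an aromatic nitrogen. For the measured compounds named here, no measured pair shows what such a change does, so its size is unknown. Because compound 2 sits at the limit of > 10000 nM in this assay, at which 3 of the 3 values shown sit, the step that the limit leaves unreadable from compound 2 to compound 4 is expected to be none beyond the scatter, most likely ending again at a limit. Compound 4 is expected to give about 15000 nM, within 3000 nM to 60000 nM.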

Compound 4, half-maximal inhibitory concentration: > 10000 nM
Compound 4: no number, only a limit (the forecaster's own chance of this, stated with the estimate: 80%); the middle value does not contradict the limit.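

No step can be read from compound 2 to compound 4, because both give only a limit of the assay, not a number: the limit of > 10000 nM in this assay, at which 4 of the 4 values shown sit.

The compounds shown leave open which change to the shared core, if any, would give measurable inhibition.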